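A hydroxy group added to the fused ring arm

This account rests on a few compounds, and the source may have more. Where it says the series, first, only, none or still open, it means among the compounds named here.

In an ADME assay on microsomes from liver (Homo sapiens) for metabolic stability, tested at 1 uM (a higher number here means that the liver removes a larger share of the compound in one pass, a lower number that the liver removes a smaller share), compound 3 `CC[C@H]1OC(=O)[C@H](C)C(=O)[C@H](C)[C@@H](O[C@@H]2O[C@H](C)C[C@H](N(C)C)[C@H]2O)[C@](C)(O)C[C@@H](C)C(=O)[C@H](C)[C@H]2N(C3CN(Cc4ccnc5ncccc45)C3)C(=O)O[C@]12C` gives 0.6, the lower of the two numbers that were read. Compound 1 `CC[C@H]1OC(=O)[C@H](C)C(=O)[C@H](C)[C@@H](O[C@@H]2O[C@H](C)C[C@H](N(C)C)[C@H]2O)[C@](C)(O)C[C@@H](C)C(=O)[C@H](C)[C@H]2N(C3CN(Cc4ccnc5cccnc45)C3)C(=O)O[C@]12C` gives 0.7 in this assay, and the two lie close: a number 0.10 lower from compound 1 to compound 3 (within the scatter). For compound 2 `CC[C@H]1OC(=O)[C@H](C)C(=O)[C@H](C)[C@@H](O[C@@H]2O[C@H](C)C[C@H](N(C)C)[C@H]2O)[C@](C)(O)C[C@@H](C)C(=O)[C@H](C)[C@H]2N(C3CN(Cc4c(O)cnc5cccnc45)C3)C(=O)O[C@]12C` this assay reports only a limit, < 0.3. Compound 4 `CC[C@H]1OC(=O)[C@H](C)C(=O)[C@H](C)[C@@H](O[C@@H]2O[C@H](C)C[C@H](N(C)C)[C@H]2O)[C@](C)(O)C[C@@H](C)C(=O)[C@H](C)[C@H]2N(C3CN(Cc4c(O)cnc5ncccc45)C3)C(=O)O[C@]12C` differs from compound 3 by hydroxy in place of hydrogen on an aromatic carbon, on an aromatic carbon of a six-membered aromatic ring with one nitrogen within a fused system of two rings. The same kind of change was measured once before, and it was large: a number at least 0.40 lower from compound 1 to compound 2 (beyond the scatter). A related comparison, a number at least 0.30 higher from compound 2 to compound 3 (beyond the scatter), points the same way. A drop of that order is therefore expected for compound 4: a number 0.35 lower from compound 3 to compound 4 (beyond the scatter). Compound 4 is estimated at 0.25, between 0.1 and 0.4, quite possibly reported only as a limit.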

Compound 4, hepatic extraction ratio: < 0.3
Compound 4: a limit, no number; the forecaster's own chance of this, stated with the estimate: 60%; the middle value lies beyond the limit too.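

On a second core, the hydroxy group on this aromatic carbon again goes with a lower number (a number at least 0.30 lower from compound 3 to compound 4 (beyond the scatter)), so the drop no longer rests on a single pair: the same change on two cores in this assay, a number at least 0.40 lower (beyond the scatter) from compound 1 to compound 2 and a number at least 0.30 lower (beyond the scatter) from compound 3 to compound 4; the limit leaves it open whether they differ. Compound 4 also sits well under the value of compound 1 (a number at least 0.40 lower from compound 1 to compound 4 (beyond the scatter)), whose fused ring arm differs and carries no hydroxy group. Compound 4 is reported only as a limit (< 0.3), and the steps that such limits leave between compounds cannot be read: the limit of < 0.3 in this assay, at which 2 of the 4 values shown sit.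

As far as these compounds go, whether a methoxy group or an amine on this same carbon would go with a similar drop stays open.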